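The source may hold more compounds than are shown below. What is called first, only, known or untested is meant among the compounds shown, and "the series" means these compounds.

Compound 1 `CC[C@@H](Nc1c(C#N)c(-c2ccc(-c3ncccc3C)cc2)nc2cnccc12)C(N)=O` is the lowest of the three numbers measured in a physicochemical assay for lipophilicity, read by HPLC, at pH 7.5 (on this read-out lower numbers stand for lower lipophilicity and higher numbers for higher lipophilicity), where compound 1 gives 2. Its nearest neighbour is compound 2 `CC(C)(CC(N)=O)c1c(C#N)c(-c2ccc(Br)cc2)nc2cnccc12`, which in this assay gives 2.1, and the furthest is compound 3 `CC[C@H](Nc1c(C#N)c(-c2ccc(Br)cc2)nc2cnccc12)C(N)=O`, which in this assay gives 2.3; both gaps lie within the scatter, so no order can be read among the three.

Going by the values given here, the only measured step, a number 0.20 log units higher from compound 2 to compound 3 (within the scatter), exchanges one open-chain group for another on the shared core and says nothing about the aryl end of the molecule. The move to compound 4 `CC[C@@H](Nc1c(C#N)c(-c2ccc(-c3cccc(C)c3)cc2)nc2cnccc12)C(N)=O` is of a different kind: 3-methylphenyl in place of 3-methylpyridin-2-yl on an aromatic carbon. Among the compounds with values here, no measured pair covers such an exchange, so the expectation rests on the structural change alone, in which a ring with one hetero atom and one hydrogen-bond acceptor gives way to a ring of carbon only with none.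

On that basis compound 4 is expected to read higher in this assay than compound 1, by an estimated a number 1.10 log units higher from compound 1 to compound 4 (beyond the scatter). The estimate for compound 4 in this assay is 3.1, with a likely range from 2.5 to 3.7.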

Compound 4, distribution coefficient: 3
Compound 4: middle estimate off by 0.10 log units, on the high side; the measured number falls inside the stated range.
By their numbers in this assay, from the lowest: compounds 1, 2 and 3 (each within the scatter of the next); then compound 4.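

Putting 3-methylphenyl in place of 3-methylpyridin-2-yl on an aromatic carbon, para to a large group, gives a number 1.00 log units higher from compound 1 to compound 4 (beyond the scatter) in this assay. Going by these compounds alone, compounds 1, 2 and 3 all lay within the scatter of one another, and the one earlier step, an exchange of open-chain groups on the shared core, was also within it, so this aryl end is the first place in the set where the read-out clearly moves. The two groups have the same heavy-atom count and differ in the ring nitrogen, counted as a hydrogen-bond acceptor, but nothing available here ties the step to that difference.

Going by these compounds, a single pair covers this exchange, so it remains open whether the same swap would give a step of like size with the other open-chain group of compound 2 on the shared core. The compounds shown also leave open how the number would respond to a pyrimidine ring, a methoxy group or an amine at this end of the molecule, or to the nitrogen standing elsewhere in the pyridine ring.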